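The source may hold more compounds than are shown below. What is called first, only, known or untested is meant among the compounds shown, and "the series" means these compounds.

In a toxicity assay on MCF7 cells (Homo sapiens) for cytotoxicity, read by MTT assay, with a stated time of 3 h (on this read-out lower numbers stand for stronger inhibition and higher numbers for weaker inhibition), three compounds built on a shared core have been measured, and none of them yields a number. Compound 1 `COc1ccc(C2=[N+]3C(=Nc4c(-c5ccccc5)c5c(n4[B-]3(F)F)-c3ccc(OC)cc3CC5)C(c3ccccc3)=C2Br)cc1` gives > 50000 nM as a limit of the assay. Compound 2 `COc1ccc2c(c1)CCc1c(-c3ccccc3)c3n(c1-2)[B-](F)(F)[N+]1=C(c2ccc(C)cc2)C(Br)=C(c2ccccc2)C1=N3` gives > 50000 nM as a limit too. Compound 3 `COc1ccc(C2=[N+]3C(=Nc4c(-c5ccccc5)c5c(n4[B-]3(F)F)-c3ccc(OC)cc3CC5)C(c3ccccc3)=C2I)cc1` gives > 50000 nM as a limit as well, so it stands with the other two and not on any readable scale. The whole set therefore rests on the limit of > 50000 nM in this assay, at which 3 of the 3 values shown sit, and nothing finer.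

Compound 4 `COc1ccc2c(c1)CCc1c(-c3ccccc3)c3n(c1-2)[B-](F)(F)[N+]1=C(c2ccc(C)s2)C(I)=C(c2ccccc2)C1=N3` carries 5-methylthiophen-2-yl in place of the 4-methoxyphenyl of compound 3, on a carbon with a double bond to nitrogen (5-methylthiophen-2-yl in place of 4-methoxyphenyl on a carbon with a double bond to nitrogen). Among the compounds with values here, two measured steps bear on this change. One is a step that the two limits leave unreadable from compound 1 to compound 2 with methyl in place of methoxy on an aromatic carbon, and the other is a step that the two limits leave unreadable from compound 1 to compound 3 with iodo in place of bromo on a double-bonded ring carbon. Neither has a size that can be carried over, and neither swaps the whole aromatic group.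

With only the limit of compound 3 at > 50000 nM to start from, no step beyond the scatter is expected in this assay and no direction can be given. The expected change is a number no higher from compound 3 to compound 4 (the limit leaves the size open) as an estimate only. Compound 4 is estimated at 50000 nM with an expected range of 20000 nM to 100000 nM and will most likely be reported as a limit again.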

Compound 4, half-maximal inhibitory concentration: > 50000 nM
Compound 4: no number, only a limit; the forecaster's own chance of this, stated with the estimate: 85%; the middle value lies on the limit itself.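

Within the data shown here, compound 4, like compound 3, gives only a limit in this assay, so no step of readable size can be taken from the swap of 4-methoxyphenyl for 5-methylthiophen-2-yl. The compounds shown leave open how any of them ranks against the others, since the whole set now rests on a single limit: the limit of > 50000 nM in this assay, at which 4 of the 4 values shown sit.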